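A few compounds are considered here, and "the series" means these few. Any claim that something is new, unique, unknown or untested is made for them only; others in the source may bear on it.

Working notes on the series. In a functional assay on SH-SY5Y cells (Homo sapiens) for cytotoxicity, read by MTT assay, with stated times of 8 h, 30 min and 12 h, tested at 5 uM (a higher number here means a stronger effect of the compound at the concentration tested, a lower number a weaker effect), compound 1 `COc1ccc(CNC(=N)[C@@H]2CCC(=O)N2Cc2ccc(F)cc2)cc1` gives 38.1%, and compound 2 `Cc1ccc(CN2C(=O)CC[C@H]2C(=N)NCc2ccc(O)cc2)cc1` gives 23.8%. Compound 2 stands lowest of the two numbers, with compound 1 the nearest at a higher value, a gap beyond the usual scatter. For the measured compounds named here, no single-change step between measured compounds is available, so the two values can only be set side by side. Compound 3 `COc1ccc(CNC(=N)[C@@H]2CCC(=O)N2Cc2ccc(C)cc2)cc1` is not yet measured in this assay. It differs from compound 2 by methyl in place of hydrogen on an oxygen on an aromatic ring, which puts the 4-methoxyphenyl of compound 1 onto the core of compound 2. Going by the values given here, a modest upward step a number 9.2 percentage points higher from compound 2 to compound 3 (within the scatter) is expected, because compound 1, the only compound carrying the methoxy, shows 38.1%. On that basis compound 3 is estimated at 33%, with a range of 18% to 48%, resting on two compounds only.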

Compound 3, a percentage reported as activity, at one concentration (the size of the read-out at that concentration, not a potency): 29.5%
For compound 3 the middle estimate is 3.5 percentage points above the measured one, within the range that was stated.
By their numbers in this assay, from the lowest: compounds 2, 3 and 1 (each within the scatter of the next, the first and the last beyond it).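

In this assay, for the compounds shown here, hydroxy to methoxy on the aromatic ring gives a number 5.7 percentage points higher from compound 2 to compound 3 (within the scatter) and methyl in place of fluoro on an aromatic carbon gives a number 8.6 percentage points lower from compound 1 to compound 3 (within the scatter) as the first single-place comparisons. At this oxygen, therefore, methyl in place of hydrogen is not resolved from the scatter, so the hydroxy and methoxy forms cannot be told apart in this read-out. The same holds for fluoro and methyl on the other aromatic ring, so neither place has yet produced a step beyond the scatter.

On these data alone, whether a longer chain such as ethyl on the oxygen, or an amine or a carboxylic acid in place of the methyl or fluoro on the aromatic carbon, would give a step beyond the scatter stays open. Nothing at hand bears on what lies behind these two steps.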